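The compounds below may be only part of what the source reports. "The series", "measured", "known", "first", "only" and "open" are said of these compounds alone.

Measured in a functional assay on MCF7 cells (Homo sapiens) for inhibition, read by resazurin assay, with a stated time of 72 h; a higher number here means a weaker inhibitor, a lower number a stronger inhibitor:
Compound 1 `CCOc1ccc(C2C(O)C(=O)N2c2cc(OC)c(OC)c(OC)c2)cc1`: 7 nM
Compound 2 `CCOc1ccc(C2C(Oc3ccccc3)C(=O)N2c2cc(OC)c(OC)c(OC)c2)cc1`: 69 nM

Compound 2 has the higher of the two numbers, which makes it the weaker inhibitor of the pair. Compound 3 `C=CC1C(=O)N(c2cc(OC)c(OC)c(OC)c2)C1c1ccc(OCC)cc1` differs from compound 2 by a single change, vinyl in place of phenoxy on a saturated ring carbon. Among the compounds with values here, one measured step bears on this ring carbon, a 9.9-fold higher number from compound 1 to compound 2 (0.99 log units; beyond the scatter), a modest step beyond the scatter, with phenyl in place of hydrogen on an oxygen. Within the data shown here, no compound measured so far carries vinyl, so this step is only a rough guide. With the phenoxy gone, part of that step is expected to be recovered, giving a smaller step in this assay towards a lower number. The expected change is a 3.5-fold lower number from compound 2 to compound 3 (0.54 log units; beyond the scatter). For compound 3 the estimated value is 20 nM, with an expected range of 6 nM to 70 nM.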

Compound 3, half-maximal inhibitory concentration: 14 nM
The estimate for compound 3 lay 1.4-fold (0.15 log units) above the measured number; low and high end bracket the measured number.
By their numbers in this assay, from the lowest: compounds 1 and 3 (each within the scatter of the next); then compound 2.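

In this assay, replacing phenoxy with vinyl on this saturated ring carbon gives a 4.9-fold lower number from compound 2 to compound 3 (0.69 log units; beyond the scatter), so the higher number of compound 2 is not shared by every replacement of the hydroxy group of compound 1. Vinyl in place of hydroxy gives a 2.0-fold higher number from compound 1 to compound 3 (0.30 log units; within the scatter), which shows that, among these three compounds, an oxygen on this carbon is not needed for a number in this range, while the change to phenoxy alone gives the higher number. The data shown offer no measured basis for explaining either step.

What the compounds leave open is whether an ethyl group, the saturated counterpart of vinyl, or a longer chain such as propyl would stay with compound 1 and compound 3. As far as these compounds go, whether an amine or a carboxylic acid on this carbon would do the same also remains open.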